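This account rests on a few compounds, and the source may have more. Where it says the series, first, only, none or still open, it means among the compounds named here.

Two compounds built on a shared core have numbers in a functional assay (B cells) with Mus musculus as the target; a lower number here means that less compound is needed, a higher number that more compound is needed for the effect. Compound 1 `Nc1nc(O)c2c(n1)n(C1OC(CO)[C@@H](O)[C@H]1O)c(=O)n2Cc1ccc(Cl)cc1` gives 14 uM in this assay. Compound 2 `C=CCn1c(=S)n(C2OC(CO)[C@@H](O)[C@H]2O)c2nc(N)nc(O)c21` gives 1 uM in this assay. Of these two numbers, compound 1 has the higher one, and the gap to compound 2 lies beyond the scatter, so compound 2 needs less compound for the same effect.

Compound 3 `Nc1nc(O)c2c(n1)n(C1OC(CO)[C@@H](O)[C@H]1O)c(=O)n2Cc1ccc([N+](=O)[O-])cc1` has not yet been measured in this assay. It comes from compound 1 by a single change: nitro in place of chloro on an aromatic carbon. Among the compounds with values here, no measured pair shows this same change, so its effect cannot be read from the numbers at hand. Nothing in the two known values points to a large move in either direction. Compound 3 is therefore expected to give about 10 uM in this assay, with a likely range from 3 uM to 40 uM. The expected 1.4-fold lower number from compound 1 to compound 3 (0.15 log units; within the scatter) is estimated to stay within the scatter.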

Compound 3, concentration for half-maximal effect: 40 uM
Estimate against measurement, compound 3: 4.0-fold (0.60 log units) below; the range from low to high includes it.
By their numbers in this assay, from the lowest: compound 2; then compound 1; then compound 3.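

In this assay, replacing the chloro of the 4-chlorobenzyl group with nitro gives a 2.9-fold higher number from compound 1 to compound 3 (0.46 log units; beyond the scatter). Within the data shown here, this modest step is the first direct reading at this position, on an aromatic carbon and para to a large group, since compound 1 and compound 2 differ in more than one place. It shows that the choice of group here can shift the number by more than the usual scatter, with nitro needing more compound than chloro. No measurement at hand bears on why the number moves.

Among these compounds, with only two groups compared at this position, no trend across groups can be drawn. From the compounds shown here alone, how an amine, a carboxylic acid or a plain hydrogen would read here remains open, as does whether the same swap would give a similar step on a different core.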